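The source may report more compounds than this note shows. Statements on the series, on what has been measured and on what is new or still open speak of the compounds shown alone.

Compound 1 `CCn1c(C(=O)NCC#N)ccc1C(CC)(CC)c1ccc(OCCC(O)(CC)CC)c(C)c1` gives 1080 nM in an assay on cells for agonist activity at vitamin D3 receptor (Homo sapiens), with a stated time of 96 h; on this read-out higher numbers stand for an effect only at larger amounts of compound and lower numbers for an effect already at smaller amounts. Compound 2 `C#CCCOC(=O)c1ccc(C(CC)(CC)c2ccc(OCCC(O)(CC)CC)c(C)c2)n1CC` gives 6030 nM. Compound 3 `CCn1c(C(=O)N(C)CC(=O)O)ccc1C(CC)(CC)c1ccc(OCCC(O)(CC)CC)c(C)c1` gives 89 nM.

Among the three, compound 3 stands at the lowest number, reached by a 12-fold lower number from compound 1 to compound 3 (1.08 log units; beyond the scatter) and by a 68-fold lower number from compound 2 to compound 3 (1.83 log units; beyond the scatter); the remaining step, a 5.6-fold higher number from compound 1 to compound 2 (0.75 log units; beyond the scatter), is modest. Compound 4 `CCn1c(C(=O)N(C)CCO)ccc1C(CC)(CC)c1ccc(OCCC(O)(CC)CC)c(C)c1` awaits measurement; it carries hydroxymethyl in place of carboxy on a saturated chain carbon bound to an amide-type nitrogen. Among the compounds with values here, no measured step makes this same exchange. The two steps that lead into compound 3 both bring in the carboxy group, and both are large, so removing it in favour of hydroxymethyl is expected to move the number upward, though likely not all the way back to compound 1. Compound 4 is therefore estimated at 400 nM, with a range from 120 nM to 1500 nM. That estimate amounts to a 4.5-fold higher number from compound 3 to compound 4 (0.65 log units; beyond the scatter).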

Compound 4, half-maximal effective concentration: 52.7 nM
Compound 4: the middle estimate sits 7.6-fold (0.88 log units) above what was measured; the measured number lies below the stated range.
By their numbers in this assay, from the lowest: compounds 4 and 3 (each within the scatter of the next); then compound 1; then compound 2.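

Carboxy is not required at this place: with hydroxymethyl on the saturated chain carbon bound to the amide-type nitrogen, the number does not move beyond the scatter (a 1.7-fold lower number from compound 3 to compound 4 (0.23 log units; within the scatter)). The large drops therefore extend to the neutral-count (2-hydroxyethyl)(methyl)amino group, which carries no carboxy (a 20-fold lower number from compound 1 to compound 4 (1.31 log units; beyond the scatter); a 110-fold lower number from compound 2 to compound 4 (2.06 log units; beyond the scatter)). Nothing available explains this result. On these data alone, whether a primary amine or a longer chain such as 3-hydroxypropyl would hold the number at this place stays open. So does whether a methoxy group could replace the terminal hydroxyl.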